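Allyl to Isobutyl on a Shared Amine-Bearing Core

This account rests on a few compounds, and the source may have more. Where it says the series, first, only, none or still open, it means among the compounds named here.

Compound 1 `C=CCNC(=C\C(=O)/C=C/c1ccc(O)c(OC)c1)/C=C/c1ccc(O)c(OC)c1` was tested in an ADME assay on EA.hy 926 cells (Homo sapiens) for inhibition, read by MTT assay, with a stated time of 72 h; a higher number here means a weaker inhibitor, a lower number a stronger inhibitor. In this assay compound 1 gives > 25000 nM, which is a limit of the assay rather than a measured number. Compound 2 `COc1cc(/C=C/C(=O)/C=C(/C=C/c2ccc(OC(C)=O)c(OC)c2)NCC(C)C)ccc1OC(C)=O` gives > 25000 nM, again only a limit. Compound 3 `CC(=O)Oc1ccc(/C=C/C(=O)/C=C(/C=C/c2ccc(OC(C)=O)cc2)NCC(C)C)cc1` gives > 25000 nM, also a limit. Compound 1 therefore stands exactly where every value shown stands, because of the limit of > 25000 nM in this assay, at which 3 of the 3 values shown sit. Compound 4 `COc1cc(/C=C/C(=O)/C=C(/C=C/c2ccc(O)c(OC)c2)NCC(C)C)ccc1O` has not yet been measured; it differs from compound 1 by isopropyl in place of vinyl on a saturated chain carbon bound to an amine nitrogen. With all three known values sitting at the limit, nothing seen here points to a step beyond the scatter in either direction, so the step that the limit leaves unreadable from compound 1 to compound 4 is expected to be small or none. Compound 4 is expected to give about 50000 nM, within 25000 nM to 200000 nM, most likely reported once more only as a limit.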

Compound 4, half-maximal inhibitory concentration: > 25000 nM
Compound 4 ended at the assay's limit; the forecaster's own chance of this, stated with the estimate: 90%; the middle value is on the limit's open side.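

No step can be read from compound 1 to compound 4, as both compounds give only a limit in this assay: the limit of > 25000 nM in this assay, at which 4 of the 4 values shown sit.

The compounds shown leave open how strong any of them really is, and whether exchanging allyl for isobutyl changes that at all.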